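The compounds below may be only part of what the source reports. "The series", "measured", "known", "first", "only" and "open" are said of these compounds alone.

Working notes on the series, all values from a functional assay on HepG2 cells (Homo sapiens) for antiproliferative activity, read by MTT assay, with a stated time of 24 h; a higher number here means a weaker inhibitor, a lower number a stronger inhibitor:

- compound 1 `COc1ccc(C(=O)/C=C/c2ccc(N3CCCC3)cc2)c2c1C=CC(C)(C)O2`: 4740 nM
- compound 2 `COc1ccc(C(=O)/C=C/c2ccc([N+](=O)[O-])cc2)c2c1C=CC(C)(C)O2`: 2610 nM
- compound 3 `COc1ccc(C(=O)/C=C/c2ccsc2)c2c1C=CC(C)(C)O2`: > 10000 nM (a limit)
- compound 4 `COc1ccc(C(=O)/C=C/c2ccc(Cl)cc2)c2c1C=CC(C)(C)O2`: not yet measured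

For compound 3 there is only a limit, > 10000 nM, and no number.

The next step is 4-chlorophenyl in place of thiophen-3-yl on a double-bonded chain carbon bound to a double-bonded chain carbon. It places 4-chlorophenyl on the double-bonded chain carbon where thiophen-3-yl stood.

Within the data shown here, two measured steps bear on this. Replacing pyrrolidin-1-yl with nitro gave a 1.8-fold lower number from compound 1 to compound 2 (0.26 log units; within the scatter). Thiophen-3-yl in place of 4-nitrophenyl gave an at least 3.8-fold higher number from compound 2 to compound 3 (0.58 log units; beyond the scatter).

Compound 4 keeps a substituted phenyl, so a return towards the values of compound 1 and compound 2 is expected in this assay, a modest drop in the number. The expected change is an at least 2.5-fold lower number from compound 3 to compound 4 (0.39 log units; beyond the scatter). For compound 4 the estimate is 4000 nM, with an expected range of 1500 nM to 10000 nM.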

Compound 4, half-maximal inhibitory concentration: > 10000 nM
Compound 4 ended at the assay's limit; the forecaster's own chance of this, stated with the estimate: 20%; middle value at least 2.5-fold (0.39 log units) from the limit.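

In this assay compound 4 gives > 10000 nM, which is a limit of the assay and not a number. A substituted phenyl on the double-bonded chain carbon therefore does not by itself keep a measurable value: chloro in place of nitro gave an at least 3.8-fold higher number from compound 2 to compound 4 (0.58 log units; beyond the scatter), and chloro in place of pyrrolidin-1-yl gave an at least 2.1-fold higher number from compound 1 to compound 4 (0.32 log units; beyond the scatter). The step from compound 3 to compound 4 cannot be read, because both values are limits: the limit of > 10000 nM in this assay, at which 2 of the 4 values shown sit.

Left open is how far compound 4 lies beyond its limit. Also open, as far as these compounds go, is whether a dimethylamino group or a carboxylic acid on that aromatic carbon would give a measurable value.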